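Hydroxy in Place of Hydrogen: From Compound 3 to Compound 4

The source may report more compounds than this note shows. Statements on the series, on what has been measured and on what is new or still open speak of the compounds shown alone.

Compound 1, `CC/C(C)=N\NC(=S)N(Cc1ccccc1)Cc1ccccc1`, in an ADME assay on Vero cells (Chlorocebus sabaeus) for cytotoxicity, read by MTT assay, with a stated time of 72 h (a higher number here means that more compound is tolerated, a lower number that less compound is tolerated), gives "not determined" (no result reported).
Compound 2, `O=[N+]([O-])c1ccccc1/C=N\NC(=S)N(Cc1ccccc1)Cc1ccccc1`, gives < 155000 nM in this assay.
Compound 3, `S=C(N/N=C\c1ccccc1)N(Cc1ccccc1)Cc1ccccc1`, gives 174000 nM in this assay.

Among the compounds with values here, compound 3 stands as the only compound with a single number in this assay. Compound 2 gives only a limit, not a number, namely (the limit of < 155000 nM in this assay, at which 1 of the 3 values shown sits). Compound 1 has no result at all. Within the data shown here, the one measured step, an at least 1.1-fold higher number from compound 2 to compound 3 (0.05 log units; that floor lies within the scatter), lies within the scatter and offers no direction.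

Compound 4, `Oc1ccccc1/C=N\NC(=S)N(Cc1ccccc1)Cc1ccccc1`, differs from compound 3 in one place: hydroxy in place of hydrogen on an aromatic carbon. Among the measured compounds shown here, no measured step involves a hydroxy group, so nothing among the three compounds bears directly on this change. For the measured compounds named here, the only comparison, a nitro group against hydrogen at the same kind of position, showed no difference beyond the scatter, and the same outcome is expected here: a 1.1-fold lower number from compound 3 to compound 4 (0.04 log units; within the scatter). Compound 4 is therefore estimated at 160000 nM, with a range from 60000 nM to 400000 nM.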

Compound 4, half-maximal cytotoxic concentration: 166000 nM
Compound 4: the middle estimate sits 1.0-fold (0.02 log units) below what was measured; low and high end bracket the measured number.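

This gives the first measured result for a hydroxy group on this aromatic carbon, ortho to a large group, in this assay. Hydroxy in place of hydrogen gives a 1.0-fold lower number from compound 3 to compound 4 (0.02 log units; within the scatter), so phenyl and 2-hydroxyphenyl cannot be told apart here, and hydroxy in place of nitro gives an at least 1.0-fold higher number from compound 2 to compound 4 (0.02 log units; that floor lies within the scatter) and offers no direction either. That second step rests on compound 2, whose entry is a limit and not a number: the limit of < 155000 nM in this assay, at which 1 of the 4 values shown sits.

Still open, from the compounds shown here alone, is whether another group at this place, such as an amine, a carboxylic acid or a methoxy group, would shift the number beyond the scatter. Going by these compounds, it also remains open whether two hydroxy groups on the same ring would give the same picture as one.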